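Swapping the Aryl Group on the Thioether Sulfur

The source may report more compounds than this note shows. Statements on the series, on what has been measured and on what is new or still open speak of the compounds shown alone.

The series shares a core in which an aromatic amide bearing a free amino group is linked through a methylene and a sulfur to a second aromatic ring. Compound 1 `COc1ccc(SCc2ccc(C(=O)Nc3ccccc3N)cc2)cc1` carries a methoxy on that ring, and in a functional assay on A-375 cells (Homo sapiens) for antiproliferative activity, read by CCK-8 assay, with a stated time of 72 h (a lower number here means a stronger inhibitor, a higher number a weaker inhibitor), compound 1 gives 3010 nM. Compound 2 `CCc1ccc(SCc2ccc(C(=O)Nc3ccccc3N)cc2)cc1` carries an ethyl instead; in this assay compound 2 gives 2420 nM. Among the compounds with values here, the only step measured so far, a 1.2-fold lower number from compound 1 to compound 2 (0.09 log units; within the scatter), shows that exchanging one small substituent for another on this ring left the readout essentially unchanged.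

Compound 3 `Nc1ccccc1NC(=O)c1ccc(CSc2ccc(Cl)cc2)cc1` carries a chlorine on the same ring; in this assay compound 3 gives "not determined" (no result reported), so there is no number from which to anchor its position. Compound 4 `Cc1cc(C)cc(SCc2ccc(C(=O)Nc3ccccc3N)cc2)c1` differs from compound 3 as follows: 3,5-dimethylphenyl in place of 4-chlorophenyl on a sulfur

Nothing measured bears directly on this pair. Within the data shown here, the one comparable step, a 1.2-fold lower number from compound 1 to compound 2 (0.09 log units; within the scatter), was within the scatter, and compounds 1 and 2 both sit in the low-micromolar region, which suggests that substituents on this ring have had little influence so far. On that basis compound 4 is expected to fall near its neighbours in this assay, with an estimated value of 2700 nM and a likely range from 1200 nM to 6000 nM.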

Compound 4, half-maximal inhibitory concentration: 3670 nM
Compound 4: the middle estimate sits 1.4-fold (0.13 log units) below what was measured; measured number inside the range.
By their numbers in this assay, from the lowest: compounds 2, 1 and 4 (each within the scatter of the next).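

Compound 4 brings a 3,5-dimethylphenyl onto the sulfur, a ring with two substituents where compounds 1 and 2 each carry one, and in this assay the change still stays small: the comparison gives a 1.5-fold higher number from compound 2 to compound 4 (0.18 log units; within the scatter) when the 4-ethylphenyl is exchanged and a 1.2-fold higher number from compound 1 to compound 4 (0.09 log units; within the scatter) when the 4-methoxyphenyl is exchanged, and neither step separates the compounds. The insensitivity seen earlier for one exchange of a single substituent therefore holds for a different substitution pattern too, and the three aryl groups with numbers on this sulfur cannot be told apart in this assay, all of them remaining in the low-micromolar region. No measurement available here offers an explanation for this flat response.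

The step from compound 3 to compound 4 cannot be read, as compound 3 has no number, so the 4-chlorophenyl group remains unplaced relative to the others. As far as these compounds go, it also remains open whether a more different group on this ring, such as an amine or a carboxylic acid, or a saturated chain in place of the aryl ring on the sulfur, would move the number beyond the scatter.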